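Isopropylsulfonyl for (trifluoromethyl)carbonyl on a stable core

The source may report more compounds than this note shows. Statements on the series, on what has been measured and on what is new or still open speak of the compounds shown alone.

Compound 1 `CC(=O)N[C@@H]1CCN(c2cc(C)nn3c(-c4ccc(C#N)cc4)c(C)nc23)C1`, compound 2 `COc1ccc(-c2c(C)nc3c(N4CC[C@@H](NC(C)=O)C4)cc(C)nn23)cc1F` and compound 3 `COc1ccc(-c2c(C)nc3c(N4CC[C@@H](NC(=O)C(F)(F)F)C4)cc(C)nn23)cc1OC` share one core and differ at the aryl group and at the group on the amine nitrogen of the saturated ring. In an ADME assay on microsomes from liver (Homo sapiens) for metabolic stability, read by LC-MS, with NADPH named in the record, with a stated time of 60 min, tested at 1 uM, in the absence of a further agent (a lower number here means that less of the compound is left, a higher number that more of the compound is left), compound 1 reaches the limit of > 95%. In this assay compound 2 likewise reaches the limit of > 95%. Compound 3 in this assay also sits at the limit of > 95%. The step that the two limits leave unreadable from compound 1 to compound 2 cannot be sized because of the limit of > 95% in this assay, at which 3 of the 3 values shown sit. Compound 4 `COc1ccc(-c2c(C)nc3c(N4CC[C@@H](NS(=O)(=O)C(C)C)C4)cc(C)nn23)cc1OC` differs from compound 3 by isopropylsulfonyl in place of (trifluoromethyl)carbonyl on an amine nitrogen. Among the measured compounds shown here, no measured step bears on this change; the three values show only the limit. Since compound 3 stands at that limit, compound 4 is expected to remain near it, with an estimated 95% (range 85% to 100%). The expected step is a number no higher from compound 3 to compound 4 (the limit leaves the size open).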

Compound 4, percent of the compound remaining: > 95%
Compound 4: no number, only a limit; the forecaster's own chance of this, stated with the estimate: 65%; the middle value lies on the limit itself.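

No step from compound 3 to compound 4 can be read, and the same holds for every pair shown: the limit of > 95% in this assay, at which 4 of the 4 values shown sit. The compounds shown leave open whether changing the aryl group or the group on the amine nitrogen affects the compound remaining.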